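Replacing the piperazine methyl with a methoxybenzyl group

The source may hold more compounds than are shown below. What is called first, only, known or untested is meant among the compounds shown, and "the series" means these compounds.

Three compounds share one core and differ only in the side group attached to the amide. Compound 1 `Cn1cnnc1SCC(=O)Nc1ccc(-c2nc(-c3ccccc3)c(-c3ccccc3)n2C)cc1` gives 86.1% in a functional assay on HT-29 cells (Homo sapiens) for cytotoxicity, read by MTT assay, with a stated time of 24 h, tested at 32 ug/mL; a higher number here means a stronger effect of the compound at the concentration tested, a lower number a weaker effect; compound 2 `Cn1c(-c2ccc(NC(=O)CSC3=NCCS3)cc2)nc(-c2ccccc2)c1-c1ccccc1` gives 59.4%; compound 3 `CCN1CCN(CC(=O)Nc2ccc(-c3nc(-c4ccccc4)c(-c4ccccc4)n3C)cc2)CC1` gives 38.8%, the lowest of the three. The changes from compound 1 to compound 2 a number 26.7 percentage points lower from compound 1 to compound 2 (beyond the scatter), from compound 1 to compound 3 a number 47.3 percentage points lower from compound 1 to compound 3 (beyond the scatter) and from compound 2 to compound 3 a number 20.6 percentage points lower from compound 2 to compound 3 (beyond the scatter) all swapped the whole side group. Compound 4 `COc1ccc(CN2CCN(CC(=O)Nc3ccc(-c4nc(-c5ccccc5)c(-c5ccccc5)n4C)cc3)CC2)cc1` instead keeps the ring of compound 3 and changes (4-methoxyphenyl in place of methyl on a saturated chain carbon bound to an amine nitrogen in a ring). For the measured compounds named here, no measured step matches this kind of change, so the expected step of a number 11.2 percentage points higher from compound 3 to compound 4 (beyond the scatter) is small and uncertain. Compound 4 is estimated at 50%, within 25% to 75%.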

Compound 4, a percentage reported as activity, at one concentration (the size of the read-out at that concentration, not a potency): 29.9%
Beside the measured number, compound 4's estimate is 20.1 percentage points above it, within the range that was stated.
By their numbers in this assay, from the lowest: compounds 4 and 3 (each within the scatter of the next); then compound 2; then compound 1.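

Compound 4 carries 4-methoxyphenyl where compound 3 has methyl, on a saturated chain carbon bound to an amine nitrogen in a ring, and a number 8.9 percentage points lower from compound 3 to compound 4 (within the scatter) is the reading in this assay for this change. At this position, then, a group of eight heavy atoms with an aromatic ring and a group of one heavy atom cannot be told apart in this cytotoxicity test. Nothing available explains this outcome.
From the compounds shown here alone, whether a plain benzyl without the methoxy, or a benzyl carrying a carboxylic acid or an amine, would read the same stays open.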